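Aryl-pyridine series: the chlorothiophene step onto compound 3

A few compounds are considered here, and "the series" means these few. Any claim that something is new, unique, unknown or untested is made for them only; others in the source may bear on it.

Measured so far, in a functional assay on MCF7 cells (Homo sapiens) for cytotoxicity, read by ELISA, with a stated time of 4 days; on this read-out higher numbers stand for weaker inhibition and lower numbers for stronger inhibition:
Compound 1, `Cc1ccsc1-c1cc(-c2ccoc2)cc(-c2ccco2)n1`, gives 18300 nM.
Compound 2, `Clc1ccc(-c2cc(-c3ccoc3)cc(-c3ccco3)n2)s1`, gives 4740 nM.
Compound 3, `Cc1ccsc1-c1cc(-c2ccc(Cl)o2)cc(-c2ccco2)n1`, gives 5570 nM.

Compound 3 stands second highest of the three numbers. Its gap to compound 2 lies within the scatter, so no order between the two can be claimed. Against compound 1 the difference is real: the step of a 3.3-fold lower number from compound 1 to compound 3 (0.52 log units; beyond the scatter) in this assay is modest but beyond the scatter.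

The next compound is compound 4, `Clc1ccc(-c2cc(-c3ccco3)nc(-c3ccc(Cl)s3)c2)o1`. Relative to compound 3 it carries one change: 5-chlorothiophen-2-yl in place of 3-methylthiophen-2-yl on an aromatic carbon.

This exact exchange has been seen once already, between compound 1 and compound 2, where it gave a 3.9-fold lower number from compound 1 to compound 2 (0.59 log units; beyond the scatter) in this assay. Within the data shown here, that is the only measured step that bears directly on the new compound. Among the measured compounds shown here, whether the exchange carries over unchanged when the 5-chlorofuran-2-yl group is already present in compound 3 is not known from these three compounds; the single precedent is the only guide.

Taken at face value, a step of similar size and direction is expected, a 3.3-fold lower number from compound 3 to compound 4 (0.52 log units; beyond the scatter), with a wider range to allow for imperfect carry-over. Compound 4 is therefore estimated at 1700 nM in this assay, within 700 nM to 4500 nM.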

Compound 4, half-maximal inhibitory concentration: 16900 nM
Beside the measured number, compound 4's estimate is 9.9-fold (1.00 log units) below it, outside the stated range (above it).
By their numbers in this assay, from the lowest: compounds 2 and 3 (each within the scatter of the next); then compounds 4 and 1 (each within the scatter of the next).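

In this assay, the exchange of 3-methylthiophen-2-yl for 5-chlorothiophen-2-yl, on the aromatic carbon next to the ring nitrogen, has no fixed effect of its own: with the 5-chlorofuran-2-yl group in place it gives a 3.0-fold higher number from compound 3 to compound 4 (0.48 log units; beyond the scatter), against the direction seen on compound 1, so the outcome at this position depends on the other group: the same change on two cores in this assay, a 3.9-fold lower number (0.59 log units; beyond the scatter) from compound 1 to compound 2 and a 3.0-fold higher number (0.48 log units; beyond the scatter) from compound 3 to compound 4, 12-fold (1.07 log units) apart, beyond the scatter of two such steps

The furan exchange turns over in the same way, giving a 3.6-fold higher number from compound 2 to compound 4 (0.55 log units; beyond the scatter) once 5-chlorothiophen-2-yl is present: the same change on two cores in this assay, a 3.3-fold lower number (0.52 log units; beyond the scatter) from compound 1 to compound 3 and a 3.6-fold higher number (0.55 log units; beyond the scatter) from compound 2 to compound 4, 12-fold (1.07 log units) apart, beyond the scatter of two such steps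

Each change therefore lowers the number only where the other is absent, and neither can be treated as a gain that transfers from one core to the other.

Still open, as far as these compounds go, is whether the reversal goes with carrying chlorine on both five-membered rings or with the loss of the methyl group, and whether it would persist with an aminomethyl group or a carboxylic acid in place of the chlorine on the thiophene. These four compounds form a single square in one assay, so they support no general rule for the series.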